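One Group Swapped on an Amide Nitrogen

A few compounds are considered here, and "the series" means these few. Any claim that something is new, unique, unknown or untested is made for them only; others in the source may bear on it.

Compound 1 (`C=C(Br)C(=O)Nc1cccc(/C=C/C(=O)Nc2cccc3ccccc23)c1`): 1160 nM
Compound 2 (`C=C(Br)C(=O)Nc1cccc(/C=C/C(=O)Nc2cccc(F)c2)c1`): 1000 nM

In a functional assay on LoVo cells (Homo sapiens) for inhibition, read by MTT assay, with a stated time of 72 h (a higher number here means a weaker inhibitor, a lower number a stronger inhibitor), compound 2 gives 1000 nM which lies within the usual scatter of compound 1 at 1160 nM so neither can be ranked above the other. Compound 3 (`C=C(Br)C(=O)Nc1cccc(/C=C/C(=O)Nc2ccc(OC)cc2)c1`) has 4-methoxyphenyl in place of 3-fluorophenyl on an amide-type nitrogen. Compound 1 (1160 nM) and compound 2 (1000 nM) also carry different groups on that nitrogen, so no step beyond the scatter is expected in this assay here. The expected 1.1-fold higher number from compound 2 to compound 3 (0.04 log units; within the scatter) stays within the scatter. For compound 3 the estimated value is 1100 nM with an expected range from 450 nM to 2700 nM in this measurement.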

Compound 3, half-maximal inhibitory concentration: 550 nM
Compound 3: the middle estimate sits 2.0-fold (0.30 log units) above what was measured; the range from low to high includes it.
By their numbers in this assay, from the lowest: compounds 3, 2 and 1 (each within the scatter of the next, the first and the last beyond it).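

In this assay this swap gives a 1.8-fold lower number from compound 2 to compound 3 (0.26 log units; within the scatter) so 4-methoxyphenyl and 3-fluorophenyl on this amide-type nitrogen cannot be ranked, even though only the entering group counts a hydrogen-bond acceptor. For the compounds shown here, compound 3 and compound 1 are the only pair of the three whose numbers lie beyond the scatter of each other, so the group at this position can shift the number measurably. No experimental evidence is available to explain these numbers.

From the compounds shown here alone, whether an amine or a simple alkyl chain could replace the aromatic ring on this nitrogen remains open.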